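Aryl change on the double-bonded carbon: compound 2 to 3

This account rests on a few compounds, and the source may have more. Where it says the series, first, only, none or still open, it means among the compounds named here.

Two members of the series have numbers in a functional assay on NCI-H460 cells (Homo sapiens) for cytotoxicity, read by MTT assay, with a stated time of 72 h; on this read-out higher numbers stand for weaker inhibition and lower numbers for stronger inhibition. Compound 1 `CN(C)CCn1cnnc1-c1cc(Oc2ccc(NC(=O)N/N=C/c3cccc(Cl)c3Cl)cc2F)ccn1` gives 72 nM. Compound 2 `CN(C)CCn1cnnc1-c1cc(Oc2ccc(NC(=O)N/N=C/c3cccc(Br)c3)cc2F)ccn1` gives 520 nM, the highest of the two numbers, the nearest being compound 1 with a number lower by the step of a 7.2-fold higher number from compound 1 to compound 2 (0.86 log units; beyond the scatter), a move brought by 3-bromophenyl in place of 2,3-dichlorophenyl on a carbon with a double bond to nitrogen.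

Compound 3 `COc1cc(/C=N/NC(=O)Nc2ccc(Oc3ccnc(-c4nncn4CCN(C)C)c3)c(F)c2)ccc1O` is not yet measured. It differs from compound 2 by 4-hydroxy-3-methoxyphenyl in place of 3-bromophenyl on a carbon with a double bond to nitrogen.

For the measured compounds named here, only one measured step bears on this position, the step from compound 1 to compound 2, which exchanged one halogenated aryl for another and was modest in size. Going by the values given here, no measured compound carries a hydroxy or methoxy group at this place, so the direction for compound 3 cannot be read from the series; the single step shows only that this position moves the read-out by a modest amount, and the number is expected to stay within a similar span around compound 2. For compound 3 the expected value in this assay is 900 nM, within a range from 250 nM to 3500 nM. The step expected by that estimate is a 1.7-fold higher number from compound 2 to compound 3 (0.24 log units; within the scatter).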

Compound 3, half-maximal inhibitory concentration: 57 nM
Beside the measured number, compound 3's estimate is 16-fold (1.20 log units) above it; the measured number lies below the stated range.
By their numbers in this assay, from the lowest: compounds 3 and 1 (each within the scatter of the next); then compound 2.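

In this assay, the change to 4-hydroxy-3-methoxyphenyl gives a 9.1-fold lower number from compound 2 to compound 3 (0.96 log units; beyond the scatter), the first sign that this place on the carbon with a double bond to nitrogen tolerates an aryl group carrying oxygen substituents and no halogen. The comparison with the other halogenated member gives a 1.3-fold lower number from compound 1 to compound 3 (0.10 log units; within the scatter), so 2,3-dichlorophenyl and 4-hydroxy-3-methoxyphenyl cannot be told apart on this read-out even though they have no substituent in common, and halogen on the aryl group does not track with the number: compound 1 and compound 2 both carry halogen, yet only compound 2 stands apart from the other two. Nothing on hand explains why two such different aryl groups land within the scatter of each other while 3-bromophenyl does not.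

The compounds shown leave open how the hydroxy and methoxy groups share in the step from compound 2, which a plain 4-hydroxyphenyl or 3-methoxyphenyl group would separate. Also open, on these data alone, is how this place responds to an aryl group carrying an amine or a carboxylic acid, or to a longer chain in place of the aryl group.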